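The source may report more compounds than this note shows. Statements on the series, on what has been measured and on what is new or still open speak of the compounds shown alone.

In an ADME assay (liver) for metabolic stability, with Liver microsome (Rattus norvegicus) as the target, using microsomes and NADPH, with a stated time of 30 min, at 37 degrees C, tested at 1 uM (on this read-out lower numbers stand for slow clearance and higher numbers for fast clearance), compound 1 `CC(O)(c1ccc(-c2ccc(S(=O)(=O)c3ccc(N)nc3)cn2)nc1)C(F)(F)F` is reported only as a limit, < 14 mL.min-1.g-1. Compound 2 `CCNc1nc(S(=O)(=O)c2ccc(N)nc2)ccc1-c1ccc(C(C)(O)C(F)(F)F)cn1` gives 42 mL.min-1.g-1 and compound 3 `CC(O)(c1ccc(-c2ccc(S(=O)(=O)c3ccc(N)nc3)nc2NC2CC2)nc1)C(F)(F)F` gives 43 mL.min-1.g-1. These two stand level, since the step of a 1.0-fold higher number from compound 2 to compound 3 (0.01 log units; within the scatter) lies within the scatter. Compound 3 is therefore the reference point for compound 4 `CC(O)(c1ccc(-c2ccc(S(=O)(=O)c3ccc(N)nc3)nc2Oc2ccccc2)nc1)C(F)(F)F`, which differs from it as follows: phenoxy in place of cyclopropylamino on an aromatic carbon. In short, phenoxy stands in place of cyclopropylamino on an aromatic carbon.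

For the measured compounds named here, only one measured step bears on this change, the step of a 1.0-fold higher number from compound 2 to compound 3 (0.01 log units; within the scatter), in which cyclopropyl replaced ethyl on a nitrogen. That step kept the nitrogen, whereas the new change removes the whole cyclopropylamino group, so it offers limited guidance and the range must stay wide. With no measured shift to carry over, no move beyond the scatter is expected in this assay, and no firm direction can be assigned. The estimate amounts to an expected 1.2-fold higher number from compound 3 to compound 4 (0.07 log units; within the scatter). Compound 4 is expected at 50 mL.min-1.g-1, with an estimated range of 20 mL.min-1.g-1 to 120 mL.min-1.g-1.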

Compound 4, intrinsic clearance in microsomes: 213 mL.min-1.g-1
Compound 4: the middle estimate sits 4.3-fold (0.63 log units) below what was measured; measured number outside the range, above it.
By their numbers in this assay, from the lowest: compounds 2 and 3 (each within the scatter of the next); then compound 4. At a limit, below all of these: compound 1.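

In this assay, for the compounds shown here, the earlier compounds showed only that this position, an aromatic carbon next to the ring nitrogen, tolerates an exchange of one amino group for another without a change beyond the scatter, as in a 1.0-fold higher number from compound 2 to compound 3 (0.01 log units; within the scatter). Compound 4 shows that the position is not indifferent to what is attached: phenoxy in place of cyclopropylamino gives a 5.0-fold higher number from compound 3 to compound 4 (0.69 log units; beyond the scatter), and phenoxy in place of ethylamino gives a 5.1-fold higher number from compound 2 to compound 4 (0.71 log units; beyond the scatter). Nothing measured here explains this faster clearance.

Phenoxy differs from cyclopropylamino at once in its linking oxygen, its aromatic ring and the hydrogen-bond donor it lacks, and the compounds shown do not separate these. An anilino group, which keeps the nitrogen alongside the aromatic ring, or a methoxy group, which keeps the oxygen without it, would begin to do so.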